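The source may hold more compounds than are shown below. What is called first, only, known or untested is meant among the compounds shown, and "the series" means these compounds.

Of the compounds shown here, two built on a shared core have been measured so far. In a functional assay on PC-3 cells (Homo sapiens) for antiproliferative activity, read by MTT assay, with a stated time of 72 h (a lower number here means a stronger inhibitor, a higher number a weaker inhibitor), compound 1 (`CCN(CC)CCCNC(=O)c1ccc(C(CC)(CC)c2ccc(C#CC(O)(CC)CC)c(C)c2)n1CC`) gives 8500 nM and compound 2 (`CCn1c(C(=O)NCCC(=O)O)ccc1C(CC)(CC)c1ccc(C#CC(O)(CC)CC)c(C)c1`) gives 5130 nM. These two values lie within the scatter of each other, so compound 2 stands level with compound 1 on the numbers available.

Compound 3 (`CCn1c(C(=O)NCCCO)ccc1C(CC)(CC)c1ccc(C#CC(O)(CC)CC)c(C)c1`) carries hydroxymethyl in place of carboxy on a saturated chain carbon, two bonds along the chain from an amide-type nitrogen. Going by the values given here, no measured compound has hydroxymethyl at this place. Among the compounds with values here, the one measured step that bears on the change exchanged (diethylamino)methyl for carboxy on the same chain carbon, and it reads a 1.7-fold lower number from compound 1 to compound 2 (0.22 log units; within the scatter). Within the data shown here, with only that single step to go on, no change beyond the scatter is expected in this assay, and neither direction is favoured. The estimated size is a 1.0-fold lower number from compound 2 to compound 3 (0.01 log units; within the scatter). For compound 3 the expected value is 5000 nM, with an estimated range from 2000 nM to 12000 nM.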

Compound 3, half-maximal inhibitory concentration: > 50000 nM
Compound 3: a limit, no number; the forecaster's own chance of this, stated with the estimate: 5%; middle value at least 10-fold (1.00 log units) away from the limit.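

Going by these compounds alone, until this point, the one exchange at this place, on a saturated chain carbon, two bonds along the chain from an amide-type nitrogen, had stayed within the scatter in this assay; hydroxymethyl in place of carboxy now gives an at least 9.7-fold higher number from compound 2 to compound 3 (0.98 log units; beyond the scatter), which shows that this place does respond to the group it carries. Measured against the remaining chain end, hydroxy in place of diethylamino on a saturated chain carbon, three bonds along the chain from an amide-type nitrogen, gives an at least 5.8-fold higher number from compound 1 to compound 3 (0.76 log units; beyond the scatter), so among these three the 3-hydroxypropyl chain alone stands apart, while compound 1 and compound 2 stay level despite their different chain ends. The reading for compound 3 is a limit of the assay and not a number, so both steps give only a smallest possible size: the limit of > 50000 nM in this assay, at which 1 of the 3 values shown sits.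

The compounds shown leave open how far compound 3 actually lies from the other two, and whether the step belongs to the hydroxy group itself. A primary amide, a methyl ester or a methoxy group at the chain end, or a longer chain ending in hydroxy, could each bear on that question.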